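From propylamino to cyclopentylamino

The source may report more compounds than this note shows. Statements on the series, on what has been measured and on what is new or still open speak of the compounds shown alone.

In an ADME assay on BCBL1 cells (Homo sapiens) for cytotoxicity, with a stated time of 7 days (on this read-out lower numbers stand for higher toxicity in this test and higher numbers for lower toxicity in this test), compound 1 (`CC(C)CSc1nc(N)nc2c1ncn2/C=C1/CC1(CO)CO`) gives > 20000 nM, which is a limit and not a number. Compound 2 (`Nc1nc(OCc2ccccc2)c2ncn(/C=C3/CC3(CO)CO)c2n1`) gives > 20000 nM, also a limit. Compound 3 (`CCCNc1nc(N)nc2c1ncn2/C=C1/CC1(CO)CO`) gives > 20000 nM, again a limit. Compound 3 thus stands at the limit of > 20000 nM in this assay, at which 3 of the 3 values shown sit, without an exact number of its own.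

Compound 4 (`Nc1nc(NC2CCCC2)c2ncn(/C=C3/CC3(CO)CO)c2n1`) differs from compound 3 by a single change, (cyclopentyl in place of propyl on a nitrogen on an aromatic ring), which puts cyclopentyl in place of propyl on a nitrogen on an aromatic ring.

Within the data shown here, three measured steps bear on this change: a step that the two limits leave unreadable from compound 1 to compound 2, a step that the two limits leave unreadable from compound 1 to compound 3 and a step that the two limits leave unreadable from compound 2 to compound 3. None of them gives a size to carry over, so they offer no reason to foresee a shift in either direction in this assay. No step beyond the usual scatter is expected, and the estimated step is a number no higher from compound 3 to compound 4 (the limit leaves the size open). The result may well be reported only as a limit again. For compound 4 the estimated value is 20000 nM, with an expected range from 10000 nM to 40000 nM.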

Compound 4, half-maximal cytotoxic concentration: 71700 nM
For compound 4 the middle estimate is 3.6-fold (0.55 log units) below the measured one; measured number above the stated range.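

No step to compound 4 can be read from compound 1, compound 2 or compound 3, because each of those three has only a limit and not a number: the limit of > 20000 nM in this assay, at which 3 of the 4 values shown sit.

From the compounds shown here alone, whether cyclopentyl in place of propyl on a nitrogen on an aromatic ring shifts this read-out at all, and by how much, stays open.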